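The compounds below may be only part of what the source reports. "The series", "measured", "known", "first", "only" and "open" are said of these compounds alone.

Measured compounds:
Compound 1 `CC(C)[C@H](NC(=O)COc1cccc2ccccc12)C(=O)N[C@@H](CC(=O)O)C(=O)COc1cccc(C(F)(F)F)c1` is a limit of the assay: in a functional assay on Jurkat cells (Homo sapiens) (a higher number here means a weaker inhibitor, a lower number a stronger inhibitor), compound 1 gives > 100000 nM.
Compound 2 `CC(C)[C@H](NC(=O)COc1cccc2ccccc12)C(=O)N[C@@H](CC(=O)O)C(=O)COc1ccc(OC(F)(F)F)cc1` gives 29100 nM in this assay.
Compound 3 `CC(C)[C@H](NC(=O)COc1cccc2ccccc12)C(=O)N[C@@H](CC(=O)O)C(=O)COc1ccc(F)cc1` is also a limit of the assay: in this assay compound 3 gives > 100000 nM.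

All three share one core, and differ only in the aryl group carried on an oxygen on a saturated carbon. Going by the values given here, compound 2 stands apart as the only one with a readable number; the other two sit at the limit of > 100000 nM in this assay, at which 2 of the 3 values shown sit. The steps show what the aryl group does: an at least 3.4-fold lower number from compound 1 to compound 2 (0.53 log units; beyond the scatter), and an at least 3.4-fold higher number from compound 2 to compound 3 (0.53 log units; beyond the scatter). The step from compound 1 to compound 3 is one that the two limits leave unreadable a step that the two limits leave unreadable from compound 1 to compound 3.

Compound 4 `CC(C)[C@H](NC(=O)COc1cccc2ccccc12)C(=O)N[C@@H](CC(=O)O)C(=O)COc1cc(F)cc(F)c1F` is not yet measured. Its change from compound 2 is 2,3,5-trifluorophenyl in place of 4-(trifluoromethoxy)phenyl on an oxygen on a saturated carbon. The trifluoromethoxy group that gave compound 2 its readable number is gone, and compound 3 shows that losing that group cost at least a modest step toward weaker inhibition. The same direction is expected here in this assay, and a return to the limit would not surprise.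

Compound 4 is therefore expected to be a weaker inhibitor than compound 2, with a step of a 2.7-fold higher number from compound 2 to compound 4 (0.44 log units; beyond the scatter). For compound 4 the estimate in this assay is 80000 nM, in a range from 25000 nM to 300000 nM.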

Compound 4, half-maximal inhibitory concentration: 30000 nM
For compound 4 the middle estimate is 2.7-fold (0.43 log units) above the measured one; the measured number falls inside the stated range.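

In this assay, the change at this position, on an oxygen on a saturated carbon, gives a 1.0-fold higher number from compound 2 to compound 4 (0.01 log units; within the scatter), so the trifluoromethoxy group is not required for a readable number, and 2,3,5-trifluorophenyl serves here as well as 4-(trifluoromethoxy)phenyl. Fluorine on the ring does not by itself settle the outcome, as two aryl groups that carry only fluorine as a substituent are separated by an at least 3.3-fold lower number from compound 3 to compound 4 (0.52 log units; beyond the scatter). The third step, an at least 3.3-fold lower number from compound 1 to compound 4 (0.52 log units; beyond the scatter), runs in the same direction as the step to compound 2, so two quite different aryl groups now give a readable number where 3-(trifluoromethyl)phenyl does not.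

Compound 1 and compound 3 are limits of the assay, not numbers: the limit of > 100000 nM in this assay, at which 2 of the 4 values shown sit. The compounds shown leave open which of the three fluorines in 2,3,5-trifluorophenyl matter, and whether an unsubstituted phenyl or a ring carrying an amine or a methoxy group at this place would also give a readable number.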